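An Oxazole Group Gives Way to a Pyrrolidinone

A few compounds are considered here, and "the series" means these few. Any claim that something is new, unique, unknown or untested is made for them only; others in the source may bear on it.

In a physicochemical assay for lipophilicity, using the shake flask method, in phosphate buffer, measured as octanol-water partition, with a stated time of 30 min, at pH 7.4 (a lower number here means a more polar compound, a higher number a more lipophilic compound), compound 1 `Cc1ncccc1-c1cnc(NCc2c(F)ccc3c2CCO3)c2nn(CC#N)c(=O)n12` gives 2.2, compound 2 `CN(c1ncco1)c1cnc(NCc2c(F)ccc3c2CCO3)n2cnnc12` gives 2.1 and compound 3 `Cc1nccn1-c1cnc(NCc2c(F)ccc3c2CCO3)c2cn[nH]c(=O)c12` gives 2.1. All three lie within the scatter of one another, with compound 2 level with compound 3. Compound 4 `C[C@@H]1CC(=O)N(c2cnc(NCc3c(F)ccc4c3CCO4)n3cnnc23)C1` carries 4-methyl-2-oxopyrrolidin-1-yl in place of methyl(1,3-oxazol-2-yl)amino on an aromatic carbon. Going by the values given here, no measured pair shows a single change, so the guide is indirect. The three measured compounds differ in several places, yet they stay close together, with compound 2 at 2.1, so a small downward step, within the scatter, is expected. The expected change is a number 0.10 log units lower from compound 2 to compound 4 (within the scatter). For compound 4 the estimated value is 2, within a range from 1.6 to 2.4.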

Compound 4, distribution coefficient: 1.8
Compound 4: middle estimate off by 0.20 log units, on the high side, and the stated range covers the measured number.
By their numbers in this assay, from the lowest: compounds 4, 2, 3 and 1 (each within the scatter of the next, the first and the last beyond it).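

Going by these compounds alone, with a number 0.30 log units lower from compound 2 to compound 4 (within the scatter) in this assay, this is the first comparison here that changes only one place, replacing methyl(1,3-oxazol-2-yl)amino with 4-methyl-2-oxopyrrolidin-1-yl. At this aromatic carbon, a five-membered aromatic ring on a nitrogen can therefore give way to a non-aromatic ring with a defined stereocentre, and the read-out stays within the scatter. Nothing here explains why the number stays there. Going by these compounds, what an amine or a carboxylic acid would give on this aromatic carbon remains open, as does the effect of the opposite stereocentre.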